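The source may report more compounds than this note shows. Statements on the series, on what has been measured and on what is new or still open speak of the compounds shown alone.

The measured compounds are:

Compound 1, `O=C(Oc1cccc(Cl)c1)c1cc2cc(CCl)ccc2oc1=O`, which in a functional assay on HT-1080 cells (Homo sapiens), read by transwell migration, with a stated time of 24 h, tested at 1 uM (on this read-out lower numbers stand for a stronger effect and higher numbers for a weaker effect at the one concentration tested), gives 79.8%.
Compound 2, `NCc1ccc2oc(=O)c(C(=O)Oc3cccc(I)c3)cc2c1`, which in this assay gives 25.3%.
Compound 3, `CC(=O)NCc1ccc2oc(=O)c(C(=O)Oc3cccc(Br)c3)cc2c1`, which in this assay gives 36.9%.

Compound 1 has the highest number of the three, and so the weakest effect in this assay. The nearest to it is compound 3, whose number lies lower by a gap beyond the usual scatter; compound 2 lies further away still, also beyond the scatter. Compounds 2 and 3 differ from compound 1 in more than one place, so no single change can be read from them.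

Compound 4, `O=C(Oc1cccc(Cl)c1)c1cc2ccccc2oc1=O`, has not yet been measured. It differs from compound 1 in one place: hydrogen in place of chloromethyl on an aromatic carbon. Among the measured compounds shown here, no pair of measured compounds differs in exactly this way, so no measured step shows what to expect from it. With the halogen on the ester kept as in compound 1, compound 4 is expected to move only moderately, with the number drifting somewhat lower, a step of a number 9.8 percentage points lower from compound 1 to compound 4 (within the scatter). In this assay compound 4 is therefore estimated at 70%, within a range from 45% to 95%.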

Compound 4, a percentage reported as activity, at one concentration (the size of the read-out at that concentration, not a potency): 45.5%
Compound 4: middle estimate off by 24.5 percentage points, on the high side; measured number inside the range.
By their numbers in this assay, from the lowest: compound 2; then compounds 3 and 4 (each within the scatter of the next); then compound 1.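

In this assay, replacing chloromethyl with hydrogen on the aromatic carbon gives a number 34.3 percentage points lower from compound 1 to compound 4 (beyond the scatter) and so a stronger effect at the one concentration tested. Among the compounds shown here, this is the first direct reading of this position: with the rest of the molecule held constant, the group placed there clearly changes the result. For this pair, chloromethyl is not needed for the effect, since the compound with only hydrogen at this position has the stronger effect of the two. Nothing measured here explains why the removal of chloromethyl has this effect.

On these data alone, the result compares only chloromethyl and hydrogen, so it remains open whether a small methyl, a hydroxymethyl or a longer chain such as chloroethyl would give a number near that of compound 4, that of compound 1 or somewhere else. As far as these compounds go, compounds 2 and 3 carry other groups at this position but also a different halogen on the ester, so they cannot settle this, and it also remains open whether the same step would appear with bromine or iodine on the ester.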